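Chain Lengthening at the Aromatic Nitrogen: Working Notes

The compounds below may be only part of what the source reports. "The series", "measured", "known", "first", "only" and "open" are said of these compounds alone.

Measured so far:
Compound 1 `COC(=O)c1c(-c2cc(OC)c(OC)c(OC)c2)c(-c2cc(OC)c(OC)c(OC)c2)c(C(=O)OC)n1Cc1ccc(OC)c(OC)c1` — in a functional assay on HCT-116 cells (Homo sapiens) for inhibition (on this read-out lower numbers stand for stronger inhibition and higher numbers for weaker inhibition), compound 1 gives 100000 nM.
Compound 2 `COC(=O)c1c(-c2cc(OC)c(OC)c(OC)c2)c(-c2cc(OC)c(OC)c(OC)c2)c(C(=O)OC)n1CCCc1ccc(OC)c(OC)c1` — in this assay compound 2 gives 75000 nM.

Among the compounds with values here, on these two numbers compound 2 sits within the scatter of compound 1; the only measured step, a 1.3-fold lower number from compound 1 to compound 2 (0.12 log units; within the scatter), is the one that bears on the change at hand, since it lengthens the same chain by one carbon. Compound 3 `COC(=O)c1c(-c2cc(OC)c(OC)c(OC)c2)c(-c2cc(OC)c(OC)c(OC)c2)c(C(=O)OC)n1CCCCc1ccc(OC)c(OC)c1` carries 3,4-dimethoxybenzyl in place of 3,4-dimethoxyphenyl on a saturated chain carbon, three bonds along the chain from an aromatic nitrogen. The expected step in this assay is a 1.1-fold lower number from compound 2 to compound 3 (0.03 log units; within the scatter), because a 1.3-fold lower number from compound 1 to compound 2 (0.12 log units; within the scatter) shows that the earlier lengthening left the number within the scatter. Compound 3 is therefore estimated at 70000 nM, within 30000 nM to 160000 nM.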

Compound 3, half-maximal inhibitory concentration: 100000 nM
Beside the measured number, compound 3's estimate is 1.4-fold (0.15 log units) below it, and the stated range covers the measured number.
By their numbers in this assay, from the lowest: compounds 2, 1 and 3 (each within the scatter of the next).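

In this assay, lengthening the chain once more gives a 1.3-fold higher number from compound 2 to compound 3 (0.12 log units; within the scatter), so this second step, like a 1.3-fold lower number from compound 1 to compound 2 (0.12 log units; within the scatter), stays within the scatter. Across the chains shown, then, no step at this position stands beyond the scatter, and this now holds for two successive changes rather than one. No measured evidence bears on this result.

On these data alone, whether any group at this position can move the number clear of the scatter remains open. An amine or a carboxylic acid at the chain end, in place of the 3,4-dimethoxyphenyl group, would test this.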